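The source may hold more compounds than are shown below. What is called first, only, known or untested is meant among the compounds shown, and "the series" means these compounds.

Compound 1 `CCOC(=O)Cn1ncc2cncn2c1=O` stands only at a limit on the numbers shown. In a functional assay for inhibition, with Homo sapiens as the target (a higher number here means a weaker inhibitor, a lower number a stronger inhibitor), compound 1 gives > 48000 nM, a limit of the assay and not a number. Compound 2 `CCOC(=O)Cn1ncc2c(C)ncn2c1=O` carries methyl in place of hydrogen on an aromatic carbon. In this assay compound 2 gives > 48000 nM, again a limit. The step that the two limits leave unreadable from compound 1 to compound 2 therefore stays unreadable, as the limit of > 48000 nM in this assay, at which 2 of the 2 values shown sit, shows. Compound 3 `CCOC(=O)Cn1ncc2cnc(COC)n2c1=O` differs by methoxymethyl in place of hydrogen on an aromatic carbon. Among the compounds with values here, no measured step bears readably on this change. For compound 3 the step expected is a step that the limit leaves unreadable from compound 1 to compound 3, with the reading expected to end at a limit once more. Compound 3 is estimated at 60000 nM, within 20000 nM to 200000 nM.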

Compound 3, half-maximal inhibitory concentration: > 48000 nM
Compound 3 gave a limit, no number (the forecaster's own chance of this, stated with the estimate: 85%); the middle value does not contradict the limit.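

No step can be read from compound 1 to compound 3, as both values are limits and not numbers: the limit of > 48000 nM in this assay, at which 3 of the 3 values shown sit.

The compounds shown leave open whether methyl or methoxymethyl in place of hydrogen changes inhibition in this assay at all.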